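Moving the Methoxy Group on a Curcumin-Type Chain

A few compounds are considered here, and "the series" means these few. Any claim that something is new, unique, unknown or untested is made for them only; others in the source may bear on it.

The study pairs two compounds that were measured in a functional assay on HCT-116 cells (Homo sapiens) for inhibition, read by sulforhodamine B assay, with a stated time of 48 h, tested at 50 uM; a higher number here means more inhibition of growth at the concentration tested, a lower number less inhibition of growth. Compound 1, `COc1cc(/C=C/C(=O)/C=C/c2cc(OC)c(OC)c(OC)c2)ccc1OCc1cn(CCOc2cc(=O)oc3ccccc23)nn1`, gives 89%. Compound 2, `COc1ccccc1/C=C/C(=O)/C=C/c1ccc(OCc2cn(CCCCCOc3cc(=O)oc4ccccc34)nn2)c(OC)c1`, gives 33%, the lower of the two numbers, and the gap between compound 2 and compound 1 lies beyond the scatter of repeated measurements.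

Compound 3, `COc1cccc(/C=C/C(=O)/C=C/c2ccc(OCc3cn(CCCCCOc4cc(=O)oc5ccccc45)nn3)c(OC)c2)c1`, has not yet been measured. It keeps every atom of compound 2 and differs from it only in how they are joined: 3-methoxyphenyl in place of 2-methoxyphenyl on a double-bonded chain carbon bound to a double-bonded chain carbon. For the measured compounds named here, no measured pair in this set shows that change, so its direction and size are not known from the data. Because compound 2 stands at 33% and compound 1 stands at 89%, there is room in either direction.

The author expects a modest rise, a number 12 percentage points higher from compound 2 to compound 3 (beyond the scatter), and estimates that compound 3 will give 45% in this assay, within a range from 20% to 75%.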

Compound 3, percent growth inhibition at one concentration: 36%
For compound 3 the middle estimate is 9 percentage points above the measured one, within the range that was stated.
By their numbers in this assay, from the lowest: compounds 2 and 3 (each within the scatter of the next); then compound 1.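

In this assay, for the compounds shown here, the first pair to isolate this change shows that 3-methoxyphenyl in place of 2-methoxyphenyl on a double-bonded chain carbon bound to a double-bonded chain carbon gives a number 3 percentage points higher from compound 2 to compound 3 (within the scatter). With everything else in the structure held the same, the two placements of the methoxy group cannot be told apart in this read-out, so this change does not account for much of the spread seen in the set so far. Nothing available explains why the two compounds read alike.

The compounds shown leave open whether an amine or a carboxylic acid in place of the methoxy group on this ring would read differently. Compound 1, at 89%, differs from compound 2 and compound 3 in more than one place, so which of those differences matters remains unresolved.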